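The source may hold more compounds than are shown below. What is called first, only, known or untested is meant among the compounds shown, and "the series" means these compounds.

Measured so far in a functional assay on the whole organism (strain Wistar) with Rattus norvegicus as the target, read by paw edema; a lower number here means that less compound is needed, a higher number that more compound is needed for the effect:

- Compound 1 `CCC(=O)NS(=O)(=O)c1ccc(-n2nc(C(F)(F)F)cc2-c2ccc(Br)cc2)cc1CO` gives 7.2 mg/kg
- Compound 2 `CCC(=O)NS(=O)(=O)c1ccc(-n2nc(C(F)(F)F)cc2-c2ccc(OC)c(C)c2)cc1CO` gives 6.2 mg/kg
- Compound 3 `CCC(=O)NS(=O)(=O)c1ccc(-n2nc(C(F)F)cc2-c2ccc(OC)c(C)c2)cc1CO` gives 6.3 mg/kg

Compound 2 at 6.2 mg/kg lies within the scatter of both other compounds, so the three cannot be put in any order. Going by the values given here, the next compound to be tested is compound 4 `CCC(=O)NS(=O)(=O)c1ccc(-n2nc(C(F)(F)F)cc2-c2ccc3c(c2)CCO3)cc1CO`, which has no measurement yet. The change from compound 2 is a group of 9 heavy atoms (8 carbon, 1 oxygen; one five-membered non-aromatic ring with 1 hetero atom, one six-membered aromatic ring of carbon only) in place of a group of 9 heavy atoms (8 carbon, 1 oxygen; one six-membered aromatic ring of carbon only), on an aromatic carbon and it sits on an aromatic carbon of a five-membered aromatic ring with 2 nitrogen. The 4-methoxy-3-methylphenyl leaves, and the entering group brings a five-membered non-aromatic ring with 1 hetero atom.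

The measured step closest to this one is a 1.2-fold lower number from compound 1 to compound 2 (0.06 log units; within the scatter) at the same place, where 4-methoxy-3-methylphenyl took the place of 4-bromophenyl. A second step, a 1.0-fold higher number from compound 2 to compound 3 (0.01 log units; within the scatter) from hydrogen in place of fluoro, lies elsewhere in the molecule and bears on the change only loosely. Among the compounds with values here, neither step leaves the scatter, although no measured compound carries the entering ring, so the evidence is indirect. In this assay the expected result is therefore no real shift, and the estimated change is a 1.0-fold higher number from compound 2 to compound 4 (0.02 log units; within the scatter) at most by a small margin. Compound 4 is expected to give about 6.5 mg/kg with an estimated range from 3.5 mg/kg to 12 mg/kg as its limits.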

Compound 4, dose for half-maximal effect: 7.5 mg/kg
Compound 4: the middle estimate sits 1.2-fold (0.06 log units) below what was measured, within the range that was stated.
By their numbers in this assay, from the lowest: compounds 2, 3, 1 and 4 (each within the scatter of the next).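

In this assay, going by these compounds alone, the group carrying a five-membered non-aromatic ring with 1 hetero atom is the first at this place to bring a second ring, and it replaces both earlier groups without a measurable effect. The step of a 1.2-fold higher number from compound 2 to compound 4 (0.08 log units; within the scatter) and the step of a 1.0-fold higher number from compound 1 to compound 4 (0.02 log units; within the scatter) both stay within the scatter, just as the earlier step between the two single-ring groups did. This place, on an aromatic carbon next to the ring nitrogen, has now taken three different groups with no step leaving the scatter, although nothing measured here accounts for that lack of response.

The compounds shown leave open whether any group at this place would move the number beyond the scatter, for example a phenyl ring carrying an amine or a carboxylic acid, or one with a longer chain in place of the methoxy. Within the data shown here, they also leave open whether the new ring would give a similar number alongside the altered fluorinated group of compound 3, since it has been seen only with the trifluoromethyl group.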